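A few compounds are considered here, and "the series" means these few. Any claim that something is new, unique, unknown or untested is made for them only; others in the source may bear on it.

Compound 3, `CC(C)Oc1cccc(NC(=O)CN2CCC(c3cccc[n+]3[O-])CC2)c1`, gives 48% in a functional assay on HEK293 cells for agonist activity at D(4) dopamine receptor (Homo sapiens), read by FLIPR (on this read-out higher numbers stand for larger maximal responses and lower numbers for smaller maximal responses), the lowest of the three measured numbers. Compound 1, `Cc1cccc(NC(=O)CN2CCC(c3ccc(O)cc3)CC2)c1`, gives 60%, and compound 2, `Cc1cccc(NC(=O)CN2CCC(c3nccs3)CC2)c1`, gives 62%. Compound 4, `O=C(CN1CCC(c2cccc[n+]2[O-])CC1)Nc1cccc(OC(F)(F)F)c1`, differs from compound 3 by trifluoromethyl in place of isopropyl on an oxygen on an aromatic ring. Among the compounds with values here, the only measured step, a number 2 percentage points higher from compound 1 to compound 2 (within the scatter), changed the group on the saturated ring and not the group on the oxygen of the aromatic ring, so it does not bear on this change; no measured pair speaks to it. With nothing pointing either way, compound 4 is expected to show a step of no change at the digits printed from compound 3 to compound 4 (within the scatter), none beyond the scatter. Compound 4 is estimated at 48%, with a range from 34% to 62%.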

Compound 4, largest response reached (reported as efficacy), in percent of the reference or control that the assay uses: 51%
Beside the measured number, compound 4's estimate is 3 percentage points below it; the measured number falls inside the stated range.
By their numbers in this assay, from the lowest: compounds 3, 4, 1 and 2 (each within the scatter of the next, the first and the last beyond it).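

In this assay, within the data shown here, the isopropoxy to trifluoromethoxy swap gives a number 3 percentage points higher from compound 3 to compound 4 (within the scatter), the first measured look at the group on this oxygen. For this pair, then, two quite different groups, one all carbon and one carrying three fluorines, cannot be told apart by maximal response. No available evidence bears on why the two read alike. On these data alone, whether a longer chain such as n-butyl or a benzyl group on that oxygen would read the same remains open. So does whether this swap would read the same with 1,3-thiazol-2-yl or 4-hydroxyphenyl on the saturated ring.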